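The compounds below may be only part of what the source reports. "The series", "measured", "known", "first", "only" and "open" are said of these compounds alone.

Working notes on the series. In an ADME assay on P388D1 cells (Mus musculus) for cytotoxicity, read by fluorescence and resazurin assay, with a stated time of 72 h (a lower number here means a stronger inhibitor, a higher number a weaker inhibitor), compound 1 (`O=C(Nc1ncc(Cc2ccncc2)s1)C1CCCCC1`) carries the entry "not determined" (no result reported) and offers no number for comparison. Compound 2 (`O=C(Nc1ncc(Cc2cccc3ccccc23)s1)C1CCCCC1`) reads > 40000 nM in this assay which is a limit of the assay and not a number. Among the compounds with values here, the evidence so far amounts to the limit of > 40000 nM in this assay, at which 1 of the 2 values shown sits, and no measured step exists.

Compound 3 (`O=C(CCC1CCCCC1)Nc1ncc(Cc2cccc3ccccc23)s1`) is the unmeasured neighbour of compound 2, with 2-cyclohexylethyl in place of cyclohexyl on a carbonyl carbon. No large move in this assay is expected: a modest shift towards stronger inhibition is the likeliest outcome, and a second reading at the limit remains quite possible. This expectation rests on compound 2 alone, whose > 40000 nM is a limit. The expected change is an at least 1.4-fold lower number from compound 2 to compound 3 (0.15 log units; that floor lies within the scatter) as a rough estimate only. For compound 3 the estimated half-maximal inhibitory concentration is 28000 nM with an expected range of 10000 nM to 40000 nM if a number is reported at all.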

Compound 3, half-maximal inhibitory concentration: 27600 nM
Compound 3: the middle estimate sits 1.0-fold (0.01 log units) above what was measured, and the stated range covers the measured number.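

Within the data shown here, compound 3 gives 27600 nM in this assay, the first single number, so with 2-cyclohexylethyl in place of cyclohexyl on a carbonyl carbon a reading is obtained inside the range of the assay. Compound 2 reads > 40000 nM, which is a limit of the assay and not a number. Going by these compounds, the change can therefore be stated only as an at least 1.4-fold lower number from compound 2 to compound 3 (0.16 log units; that floor lies within the scatter), so its full size remains unknown, and the only firm statement about the direction of this change rests on a single reference point: the limit of > 40000 nM in this assay, at which 1 of the 3 values shown sits.

Open, on these data alone, is how this place on a carbonyl carbon would read in this assay with a longer chain than 2-cyclohexylethyl, or with a group carrying an amine or a carboxylic acid, since both compounds with values here carry only carbon in the group at this place. Among these compounds, also open is whether the other end of the shared core matters at all, as compound 1 gives "not determined" (no result reported) and so offers no comparison with the compounds that share its cyclohexyl group.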